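Fluoro-to-methyl swap on the fused ring of compound 3

The compounds below may be only part of what the source reports. "The series", "measured", "known", "first", "only" and "open" are said of these compounds alone.

Compound 3 `COc1cccc(S(=O)(=O)c2cnc3ccc(F)cc3c2N2CCC(C)CC2)c1` holds the highest of the three numbers in an assay on isolated protein for displacement of a labelled ligand from metabotropic glutamate receptor 5 (Homo sapiens), with a stated time of 60 min, tested at 1 uM (on this read-out higher numbers stand for more inhibition at the one concentration tested (going by the name of the read-out) and lower numbers for less inhibition), giving 90%. The gap to compound 1 `COc1ccc(S(=O)(=O)c2cnc3ccc(F)cc3c2N2CCC(C)CC2)cc1`, which gives 85%, is a number 5 percentage points higher from compound 1 to compound 3 (within the scatter) and stays within the scatter. Compound 2 `Cc1ccc(S(=O)(=O)c2cnc3ccc(C)cc3c2N2CCC(C)CC2)cc1` gives 82%, also within the scatter of compound 3, so no order among the three can be claimed. Compound 4 `COc1cccc(S(=O)(=O)c2cnc3ccc(C)cc3c2N2CCC(C)CC2)c1` differs from compound 3 by methyl in place of fluoro on an aromatic carbon. For the measured compounds named here, no measured step covers this exact change: compound 1 carries fluoro and compound 2 carries methyl at that position, but the two also differ on the sulfonyl aryl group, so only their values can be compared, and those sit within the scatter of each other. Going by the values given here, the single measured step, from compound 1 to compound 3, concerns the methoxyphenyl and is itself within the scatter. Among the compounds with values here, every number so far lies in a narrow band, so compound 4 is expected to give about 87% in this assay, between 77% and 95%, a step of a number 3 percentage points lower from compound 3 to compound 4 (within the scatter) that is expected to stay within the scatter.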

Compound 4, a percentage reported as inhibition, at one concentration (the size of the read-out at that concentration, not a potency): 96%
Estimate against measurement, compound 4: 9 percentage points below; the measured number lies above the stated range.
By their numbers in this assay, from the lowest: compounds 2, 1, 3 and 4 (each within the scatter of the next, the first and the last beyond it).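

In this assay, the swap of fluoro for methyl on an aromatic carbon of the six-membered carbon ring can now be read directly: a number 6 percentage points higher from compound 3 to compound 4 (within the scatter), so fluoro and methyl cannot be told apart at this position while 3-methoxyphenyl sits on the sulfonyl sulfur. For the compounds shown here, with methyl held at this position, the change on the sulfonyl sulfur gives the first step beyond the scatter, a number 14 percentage points higher from compound 2 to compound 4 (beyond the scatter), and it is a modest one. Nothing measured here gives a reason for either step.

The compounds shown leave open whether a carboxylic acid or an amine on this aromatic carbon would keep the inhibition at this level. They also leave open whether the swap of fluoro for methyl reads the same with 4-methoxyphenyl on the sulfonyl sulfur.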